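The source may report more compounds than this note shows. Statements on the series, on what has been measured and on what is new or still open speak of the compounds shown alone.

Measured compounds:
compound 1 `CCCCCCCCCCCC(=O)OC[C@H](CSC[C@@H](N)C(=O)NCCO)OC(=O)CCCCCCCCCCC`: 24 nM
compound 2 `CCCCCCCCCCCC(=O)OC[C@H](CSC[C@@H](N)C(=O)NC1(CO)CC1)OC(=O)CCCCCCCCCCC`: 265 nM
compound 3 `CCCCCCCCCCCC(=O)OC[C@H](CSC[C@@H](N)C(=O)NCCCS(=O)(=O)O)OC(=O)CCCCCCCCCCC`: 5560 nM

In an assay on HEK293 cells for agonist activity at Toll-like receptor 2 (Homo sapiens) (on this read-out higher numbers stand for an effect only at larger amounts of compound and lower numbers for an effect already at smaller amounts), compound 1 stands lowest of the three numbers; the nearest is compound 2 with an 11-fold higher number from compound 1 to compound 2 (1.04 log units; beyond the scatter) and the furthest compound 3 with a 230-fold higher number from compound 1 to compound 3 (2.36 log units; beyond the scatter). Compound 4 `CCCCCCCCCCCC(=O)OC[C@H](CSC[C@@H](N)C(=O)NCCCCCC(=O)O)OC(=O)CCCCCCCCCCC` differs from compound 1 by 3-carboxypropyl in place of hydroxy on a saturated chain carbon, two bonds along the chain from an amide-type nitrogen. For the measured compounds named here, the step that bears most on this is the one to compound 3, which also puts an acid on a longer chain at the same place and gave a 230-fold higher number from compound 1 to compound 3 (2.36 log units; beyond the scatter); the smaller change to compound 2 already gave an 11-fold higher number from compound 1 to compound 2 (1.04 log units; beyond the scatter). Going by the values given here, a large step upward is therefore expected, though 3-carboxypropyl is not sulfomethyl and no measured pair separates the two acids. Compound 4 is expected to give 1500 nM, with an estimated range of 300 nM to 8000 nM. The expected step is a 63-fold higher number from compound 1 to compound 4 (1.80 log units; beyond the scatter).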

Compound 4, half-maximal effective concentration: 108 nM
Beside the measured number, compound 4's estimate is 14-fold (1.14 log units) above it; measured number outside the range, below it.
By their numbers in this assay, from the lowest: compound 1; then compound 4; then compound 2; then compound 3.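

In this assay, replacing hydroxy with 3-carboxypropyl gives only a 4.5-fold higher number from compound 1 to compound 4 (0.65 log units; beyond the scatter), so at this place a longer chain carrying a carboxylic acid does not bring the large rise seen with the sulfonic acid, as a 51-fold lower number from compound 3 to compound 4 (1.71 log units; beyond the scatter) shows. The same chain even compares favourably with 1-(hydroxymethyl)cyclopropyl on the amide-type nitrogen, with a 2.5-fold lower number from compound 2 to compound 4 (0.39 log units; beyond the scatter). No measurement on hand accounts for these differences.

The kind of acid and the length of the chain remain unseparated. A carboxylic acid on the shorter chain of compound 3, or an amine on the longer chain of compound 4, would help to part them.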